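Shifting a Thiophene Attachment in a Weakly Cytotoxic Series

The source may hold more compounds than are shown below. What is called first, only, known or untested is meant among the compounds shown, and "the series" means these compounds.

Compound 1, `c1csc(-c2cc(-c3ccoc3)cc(-c3cccs3)n2)c1` — in a functional assay on DU-145 cells (Homo sapiens) for cytotoxicity, with a stated time of 3 days (a lower number here means a stronger inhibitor, a higher number a weaker inhibitor), compound 1 gives > 100000 nM, which is a limit of the assay rather than a number.
Compound 2, `Clc1ccc(-c2cc(-c3cccs3)nc(-c3cccs3)c2)o1` — in this assay compound 2 gives 88100 nM.
Compound 3, `Cc1ccsc1-c1cc(-c2ccco2)cc(-c2cccs2)n1` — in this assay compound 3 gives > 100000 nM, again a limit of the assay rather than a number.

Compound 3 therefore stands at the edge of what this assay can report, and it shares that position with compound 1: the limit of > 100000 nM in this assay, at which 2 of the 3 values shown sit. Compound 4, `Cc1ccsc1-c1cc(-c2ccco2)cc(-c2ccsc2)n1`, has not yet been measured. It differs from compound 3 in one place: thiophen-3-yl in place of thiophen-2-yl on an aromatic carbon. Among the measured compounds shown here, the only measured step in this set is an at least 1.1-fold lower number from compound 1 to compound 2 (0.05 log units; that floor lies within the scatter), which swaps one furan for another; it does not move a thiophene, and its size lies within the scatter, so it gives no sign that a change of this kind shifts the read-out. For the measured compounds named here, no measured pair shows a thiophen-2-yl replaced by a thiophen-3-yl. On this evidence the step that the limit leaves unreadable from compound 3 to compound 4 is expected to be none beyond the scatter. Compound 4 is expected to give 150000 nM, within a range from 50000 nM to 500000 nM, and most likely only a limit will be reported for it.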

Compound 4, half-maximal inhibitory concentration: > 100000 nM
Compound 4 ended at the assay's limit; the forecaster's own chance of this, stated with the estimate: 75%; the middle value does not contradict the limit.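

No step can be read between compound 3 and compound 4, because both stop at the same limit of the assay rather than at a number: the limit of > 100000 nM in this assay, at which 3 of the 4 values shown sit.

As far as these compounds go, whether thiophen-3-yl in place of thiophen-2-yl changes the result in this assay at all stays open, as does how far beyond that limit compound 3 and compound 4 lie.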